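The compounds below may be only part of what the source reports. "The series", "measured", "known", "first", "only" and "open" are said of these compounds alone.

Measured so far:
compound 1 `COCC(C(=O)N1CCN(c2cccc(C(F)(F)F)c2)CC1)N1C(=O)CCC1=O`: 0%
compound 2 `CC(C(=O)N1CCN(c2ccc(Cl)cc2)CC1)N1C(=O)CCC1=O`: 0%
compound 3 `CC(C(=O)N1CCN(c2ccccc2C(F)(F)F)CC1)N1C(=O)CCC1=O`: 0%

All three were tested in a functional assay on the whole organism (strain Swiss) with Mus musculus as the target, in the maximal electroshock model, with a stated time of 2 h, at a dose of 100 mg/kg by the intraperitoneal route; a higher number here means a stronger effect of the compound at the dose given, a lower number a weaker effect. Compound 1 gives 0%, and compound 2 and compound 3 give the same reading, so compound 1 stands level with both at the digits recorded; its gap to compound 2 and its gap to compound 3 both lie within the usual scatter of this kind of measurement, and no ordering among the three can be drawn. They share a common core, yet their readings do not differ.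

Compound 4 `CC(C(=O)N1CCN(c2cccc(C(F)(F)F)c2)CC1)N1C(=O)CCC1=O` has not yet been measured. It differs from compound 1 in one place: hydrogen in place of methoxy on a saturated chain carbon, two bonds along the chain from an amide-type nitrogen in a ring and a carbonyl carbon. Compound 2 already carries hydrogen at that chain carbon, with a different group elsewhere, and gives 0%. With every tested compound of this set at the same reading, no step beyond the scatter is expected. The step from compound 1 to compound 4 is expected to be no change at the digits printed from compound 1 to compound 4 (within the scatter). Compound 4 is therefore estimated at 0%, with an expected range from 0% to 15%.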

Compound 4, a percentage reported as activity, at one dose (the size of the read-out at that dose, not a potency): 0%
Beside the measured number, compound 4's estimate shows no gap at the digits printed, and the stated range covers the measured number.
By their numbers in this assay, from the lowest: compounds 1, 2, 3 and 4 (each within the scatter of the next).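

In this assay, within the data shown here, putting hydrogen in place of methoxy on the saturated chain carbon gives no change at the digits printed from compound 1 to compound 4 (within the scatter), the first comparison here in which only this one place differs. With methoxy or with hydrogen at this carbon and the rest of the structure held the same, the reading stays the same, so this change alone does not raise the effect at the dose given. No measured information is available to explain this result.

As far as these compounds go, whether an amine, a carboxylic acid or a longer chain at this carbon would give a different reading remains open. Also open, from the compounds shown here alone, is whether the change from methoxy to hydrogen would matter in a related compound whose reading in this assay is above zero.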